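Swapping a benzylamino for dimethylamino on a weak nucleoside

This account rests on a few compounds, and the source may have more. Where it says the series, first, only, none or still open, it means among the compounds named here.

The series centres on nucleoside-like compounds carrying substituents on a shared core, tested in a functional assay on the whole organism (Pleural cavity) with Rattus norvegicus as the target; on this read-out lower numbers stand for an effect already at smaller amounts and higher numbers for an effect only at larger amounts of compound. Among the measured compounds shown here, compound 1 `OC[C@H]1OC(n2cnc3c(SCc4ccccc4)nccc32)[C@H](O)[C@@H]1O` is the one member with a numerical result: in this assay compound 1 gives 9 mg/kg. Compound 2 `[O-][n+]1ccc2[nH]cnc2c1`, a small charged fragment without the sugar, reaches only a limit of the assay, giving > 9 mg/kg in this assay. Compound 3 `OC[C@H]1O[C@@H](n2cnc3c(NCc4ccccc4)nccc32)C[C@@H]1O` likewise reaches only a limit, giving > 9 mg/kg in this assay. Compound 3 therefore stands with compound 2 at the limit of > 9 mg/kg in this assay, at which 2 of the 3 values shown sit, while compound 1 alone sits at a number.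

Compound 4 `CN(C)c1nccc2c1ncn2[C@H]1C[C@H](O)[C@@H](CO)O1` is the next member to be measured. It differs from compound 3 in one place: dimethylamino in place of benzylamino on an aromatic carbon. The sugar and the shared core are untouched.

For the measured compounds named here, no measured step in this assay links compounds that differ in a single place, so there is no directly comparable change to lean on. Since compound 3 gives > 9 mg/kg, the most that can be said is that compound 4 is expected to remain in the weak region, with a step that the limit leaves unreadable from compound 3 to compound 4 that is not expected to exceed the scatter. For compound 4 the estimate in this assay is 12 mg/kg, within a range from 5 mg/kg to 30 mg/kg.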

Compound 4, dose for half-maximal effect: > 9 mg/kg
Compound 4: only a limit was reported; the forecaster's own chance of this, stated with the estimate: 60%; the middle value does not contradict the limit.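

In this assay compound 4 gives only a limit, > 9 mg/kg, and compound 3 also has only a limit, so the step between them cannot be read. Compound 4 joins compound 2 and compound 3 here: the limit of > 9 mg/kg in this assay, at which 3 of the 4 values shown sit.

The compounds shown leave open whether dimethylamino and benzylamino differ at all in this assay.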